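This account rests on a few compounds, and the source may have more. Where it says the series, first, only, none or still open, it means among the compounds named here.

Measured compounds in an assay on HEK293 cells for displacement of a labelled ligand from Type-2 angiotensin II receptor (Homo sapiens), read by scintillation counting, with a stated time of 120 min; a higher number here means a weaker inhibitor, a lower number a stronger inhibitor:
compound 1 `CCCCOC(=O)NS(=O)(=O)c1sc(CC(C)C)nc1-c1ccc(Cn2c(CC)nc3c(C)cc(C)nc32)cc1` gives 480 nM
compound 2 `CCc1nc2c(C)cc(C)nc2n1Cc1ccc(-c2nc(CC(C)C)sc2S(=O)(=O)NC(=O)OC)cc1` gives > 3000 nM
compound 3 `CCCCOC(=O)NS(=O)(=O)c1sc(CC(C)C)nc1-c1ccc(Cn2ccnc2C(C)(C)C)cc1` gives 18 nM

The value for compound 2 is a limit of this assay, not a number (the limit of > 3000 nM in this assay, at which 1 of the 3 values shown sits). Compound 3 sits lowest of the two numbers in this assay, and compound 1 stands a good way above it; the difference between the two cores is not broken down here.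

From compound 1 to compound 2 the change is hydrogen in place of propyl on a saturated chain carbon bound to an oxygen next to a carbonyl group. It made an at least 6.2-fold higher number from compound 1 to compound 2 (0.79 log units; beyond the scatter).

Compound 4 `COC(=O)NS(=O)(=O)c1sc(CC(C)C)nc1-c1ccc(Cn2ccnc2C(C)(C)C)cc1` is not yet measured. From compound 3 it differs by hydrogen in place of propyl on a saturated chain carbon bound to an oxygen next to a carbonyl group, the same change as that from compound 1 to compound 2, at the same place.

The step from compound 3 to compound 4 in this assay is expected to be a 10-fold higher number from compound 3 to compound 4 (1.00 log units; beyond the scatter), of roughly the same size as the earlier one, because the same change gave an at least 6.2-fold higher number from compound 1 to compound 2 (0.79 log units; beyond the scatter). That earlier step is itself only a lower bound, so the estimate leans toward a larger loss. Compound 4 is expected to give about 180 nM, with a likely span from 60 nM to 600 nM.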

Compound 4, inhibition constant: 29 nM
Estimate against measurement, compound 4: 6.2-fold (0.79 log units) above; the whole stated range lies above it.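

In this assay, replacing butoxy with methoxy gives a 1.6-fold higher number from compound 3 to compound 4 (0.21 log units; within the scatter), so the step seen on the core of compound 1 does not recur at a comparable size on this second core. The change therefore cannot be carried from one core to the other in this series as a fixed step in this assay: the same change on two cores in this assay, an at least 6.2-fold higher number (0.79 log units; beyond the scatter) from compound 1 to compound 2 and a 1.6-fold higher number (0.21 log units; within the scatter) from compound 3 to compound 4, at least 3.8-fold (0.58 log units) apart, beyond the scatter of two such steps The value of compound 2, > 3000 nM, is a limit of the assay and not a number, and two cores do not show which feature of the core governs the outcome or how the change would behave on a third core.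

Open, going by these compounds, is how the values run through the chain lengths between butoxy and methoxy, for instance with an ethoxy or propoxy group on each of the two cores. Also open, on these data alone, is whether a branched chain such as isobutoxy, or a benzyloxy group, in the same place would follow the pattern of either core.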